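This account rests on a few compounds, and the source may have more. Where it says the series, first, only, none or still open, it means among the compounds named here.

Four compounds built on one shared core were compared for cytotoxicity. Compound 1 `COc1ccc(Nc2nnnn2-c2cccc(Br)c2)cc1`, compound 2 `COc1ccc(Nc2nnnn2-c2cccc(F)c2)cc1` and compound 3 `COc1ccc(Nc2nnnn2-c2ccc(F)cc2)cc1` have been measured; compound 4 `COc1ccc(Nc2nnnn2-c2ccc(Br)cc2)cc1` has not.

In an ADME assay on V79 cells (Cricetulus griseus) for cytotoxicity, read by MTT assay, with a stated time of 72 h (on this read-out lower numbers stand for stronger inhibition and higher numbers for weaker inhibition), compound 1 gives 124000 nM. In this assay compound 2 gives 123000 nM, and compound 3 gives 145000 nM. All three numbers sit close together: a 1.0-fold higher number from compound 2 to compound 1 (0.00 log units; within the scatter), a 1.2-fold higher number from compound 2 to compound 3 (0.07 log units; within the scatter) and a 1.2-fold higher number from compound 1 to compound 3 (0.07 log units; within the scatter).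

The change that separates compound 2 from compound 1 is bromo in place of fluoro on an aromatic carbon. The change from compound 3 to compound 4 is of the same kind, (bromo in place of fluoro on an aromatic carbon), but not the same: in compound 1 the bromo sits meta to a large group, in compound 4 it sits para to a large group. The cores of compound 2 and compound 3 themselves differ by 4-fluorophenyl in place of 3-fluorophenyl on an aromatic nitrogen.

Within this set, the only measured instance of swapping fluoro for bromo is the step of a 1.0-fold higher number from compound 2 to compound 1 (0.00 log units; within the scatter), which is within the scatter. Compound 4 is therefore expected to stay near compound 3, with an estimated step of a 1.0-fold lower number from compound 3 to compound 4 (0.02 log units; within the scatter), because a 1.0-fold higher number from compound 2 to compound 1 (0.00 log units; within the scatter) gave no meaningful movement and compound 3 already stands at 145000 nM. The expected value for compound 4 in this assay is 140000 nM, with a plausible range from 70000 nM to 280000 nM.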

Compound 4, half-maximal inhibitory concentration: 125000 nM
Compound 4: the middle estimate sits 1.1-fold (0.05 log units) above what was measured; low and high end bracket the measured number.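

In this assay, the swap of fluoro for bromo gives a 1.2-fold lower number from compound 3 to compound 4 (0.06 log units; within the scatter), while the two steps that move the halogen-bearing phenyl on the aromatic nitrogen read a 1.0-fold higher number from compound 2 to compound 4 (0.01 log units; within the scatter) and a 1.0-fold higher number from compound 1 to compound 4 (0.00 log units; within the scatter). Set beside the earlier instance, the same change shows no measurable difference between the two cores: the same change on two cores in this assay, a 1.0-fold higher number (0.00 log units; within the scatter) from compound 2 to compound 1 and a 1.2-fold lower number (0.06 log units; within the scatter) from compound 3 to compound 4, 1.2-fold (0.07 log units) apart, within the scatter of two such steps. For the compounds shown here, this shows that in these two pairs the swap leaves the number within the scatter, whether the bromo ends up in the 3-bromophenyl of compound 1 or the 4-bromophenyl of compound 4, but it does not show that the swap would stay without effect on a core with a much lower number, nor does it set a general rule for the series, since it rests on only two pairs.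

The compounds shown vary only fluoro and bromo on the phenyl group, with the rest of the shared core unchanged throughout. From the compounds shown here alone, what an amine, a carboxylic acid or a longer alkyl chain in that place would do to the number stays open, as does whether any substituent there would move it beyond the scatter.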